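The source may hold more compounds than are shown below. What is called first, only, known or untested is meant among the compounds shown, and "the series" means these compounds.

Working notes on the shared core. Compound 1 `Nc1cc(N)c2nc(-c3ccccc3)c(NCc3ccc(Cl)c(Cl)c3)nc2c1` gives 15500 nM in a functional assay on SF-295 cells (Homo sapiens) for inhibition, read by sulforhodamine B assay, with a stated time of 48 h; on this read-out higher numbers stand for weaker inhibition of growth and lower numbers for stronger inhibition of growth. Compound 2 `COc1ccc(CNc2nc3cc(N)cc(N)c3nc2-c2ccccc2)cc1OC` gives 13200 nM in this assay. Going by the values given here, the one step between measured compounds that differ in a single place, a 1.2-fold lower number from compound 1 to compound 2 (0.07 log units; within the scatter), concerns a 3,4-dimethoxyphenyl in place of a 3,4-dichlorophenyl on the saturated chain carbon bound to the ring nitrogen, not the thioether-linked aryl. Compound 3 `COc1ccc(Sc2nc3cc(N)cc(N)c3nc2-c2ccccc2)cc1` stands apart: in this assay compound 3 gives < 100000 nM, which is a limit of the assay and not a number, (the limit of < 100000 nM in this assay, at which 1 of the 3 values shown sits). Compound 4 `Nc1cc(N)c2nc(-c3ccccc3)c(Sc3ccc(F)cc3)nc2c1` is to be measured in this assay. Its change from compound 3 is fluoro in place of methoxy on an aromatic carbon. Among the compounds with values here, no measured step bears on a change of this kind on the thioether-linked aryl; the only measured step, a 1.2-fold lower number from compound 1 to compound 2 (0.07 log units; within the scatter), sits on a different part of the molecule and is within the scatter. With compound 3 known only as a limit, there is no number from which a step could be counted, and the expectation for compound 4 rests on that limit alone. Compound 4 is therefore expected to give 50000 nM, with a range from 15000 nM to 100000 nM, and a fair chance that only a limit is again reported. The step that the limit leaves unreadable from compound 3 to compound 4 is expected to be small relative to the wide range, with no move beyond the scatter that the data would support.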

Compound 4, concentration for 50% growth inhibition: 13800 nM
Compound 4: the middle estimate sits 3.6-fold (0.56 log units) above what was measured; the measured number lies below the stated range.
By their numbers in this assay, from the lowest: compounds 2, 4 and 1 (each within the scatter of the next).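

No step can be read from compound 3 to compound 4, because compound 3 stands only as a limit of the assay and not as a number: the limit of < 100000 nM in this assay, at which 1 of the 4 values shown sits. In this assay the compounds shown leave open whether fluoro in place of methoxy on the thioether-linked aryl changes growth inhibition at all, and in which direction.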